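Furan on the Ring Nitrogen in Place of Fluorobenzyl

A few compounds are considered here, and "the series" means these few. Any claim that something is new, unique, unknown or untested is made for them only; others in the source may bear on it.

Compound 1 `CCOC(=O)c1ccc(-c2nn(Cc3ccccc3F)c3ccccc23)cc1`: in a functional assay on cells (Platelet, Homo sapiens) for inhibition (on this read-out lower numbers stand for stronger inhibition and higher numbers for weaker inhibition), compound 1 gives > 10000 nM, a limit of the assay.
Compound 2 `CCOC(=O)c1ccc(-c2nn(Cc3ccc(F)cc3)c3ccccc23)cc1`: in this assay compound 2 gives > 10000 nM, a limit of the assay.
Compound 3 `CCOC(=O)c1cccc(-c2nn(Cc3ccccc3)c3ccccc23)c1`: in this assay compound 3 gives > 10000 nM, a limit of the assay.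

Compound 2 stands at the limit of > 10000 nM in this assay, at which 3 of the 3 values shown sit, so no number is known for it. Going by the values given here, the only measured step, a step that the two limits leave unreadable from compound 1 to compound 2, gives no readable size. Compound 4 `CCOC(=O)c1ccc(-c2nn(-c3ccco3)c3ccccc23)cc1` differs from compound 2 by furan-2-yl in place of 4-fluorobenzyl on an aromatic nitrogen. Among the compounds with values here, no measured step touches this kind of change, so the expectation rests on the limits alone. Compound 4 is estimated at 15000 nM, with a range from 3000 nM to 60000 nM, most likely again reported only as a limit. This amounts to an expected step that the limit leaves unreadable from compound 2 to compound 4, not beyond the scatter.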

Compound 4, half-maximal inhibitory concentration: > 10000 nM
Compound 4 was reported as a limit; the forecaster's own chance of this, stated with the estimate: 80%; the middle value does not contradict the limit.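

Compound 4, like compound 1 and compound 2, is reported only as a limit of the assay, so neither step to compound 4 can be read: the limit of > 10000 nM in this assay, at which 4 of the 4 values shown sit.

The compounds shown leave open which group on the aromatic nitrogen, if any, gives measurable inhibition in this assay.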